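A few compounds are considered here, and "the series" means these few. Any claim that something is new, unique, unknown or untested is made for them only; others in the source may bear on it.

Measured so far:
compound 1, `COc1cc(NC(=O)Nc2cc(Nc3ccc(C(C)(C)C)cc3)ncn2)cc(OC)c1` — 47.7%
compound 2, `CCc1ccc(Nc2cc(NC(=O)Nc3c(Cl)cccc3Cl)ncn2)cc1` — 39.5%

In a functional assay on NCI-H226 cells (Homo sapiens) for inhibition, read by MTT assay, with a stated time of 48 h, tested at 10 uM (on this read-out lower numbers stand for less inhibition and higher numbers for more inhibition at the one concentration tested (going by the name of the read-out)), compound 1 gives 47.7%, and compound 2 gives 39.5%. Of these two numbers compound 1 sits at the top, but compound 2 lies within the usual scatter of it, so the two readings cannot be told apart; each shows only partial inhibition at the single concentration tested. For the measured compounds named here, compound 2 also carries a different ring pattern around the shared core, so no pair of measured compounds differs in a single place, and there is no measured step to lean on.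

Compound 3, `COc1cc(NC(=O)Nc2cc(Nc3ccc(OC)c(I)c3)ncn2)cc(OC)c1`, has not yet been tested in this assay. It differs from compound 1 in one place: 3-iodo-4-methoxyphenyl in place of 4-(tert-butyl)phenyl on a nitrogen on an aromatic ring. Going by the values given here, no measured step covers a change at this nitrogen. The expectation is that the step from compound 1 to compound 3 stays within the scatter, in no particular direction. Compound 3 is therefore estimated to give about 45% in this assay, with a range from 20% to 70%. The estimated step of a number 2.7 percentage points lower from compound 1 to compound 3 (within the scatter) is expected to fall within the scatter.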

Compound 3, a percentage reported as inhibition, at one concentration (the size of the read-out at that concentration, not a potency): 40.1%
For compound 3 the middle estimate is 4.9 percentage points above the measured one, within the range that was stated.
By their numbers in this assay, from the lowest: compounds 2, 3 and 1 (each within the scatter of the next).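

For the compounds shown here, this is the first measured step at this nitrogen: in this assay, placing 3-iodo-4-methoxyphenyl where 4-(tert-butyl)phenyl stood gives a number 7.6 percentage points lower from compound 1 to compound 3 (within the scatter) on the reading. The two groups are clearly different, since one is built of carbon alone while the other brings in oxygen, iodine and a hydrogen-bond acceptor, yet this read-out cannot tell them apart at the one concentration tested. No supporting data accompany these numbers that could say why the two readings lie so close together.

From the compounds shown here alone, with a single step at a single concentration, it remains open whether the iodine or the methoxy on the new ring matters at all when taken alone, and whether the two compounds would also stay together at other concentrations. Going by these compounds, it is equally open what a quite different group on this nitrogen, such as a morpholine-bearing phenyl ring, a carboxylic acid or a longer alkyl chain, would do to the inhibition seen in this assay for this series.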